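Tolerance of a chalcone amide series toward Vero cells

This account rests on a few compounds, and the source may have more. Where it says the series, first, only, none or still open, it means among the compounds named here.

In an ADME assay on Vero cells (Chlorocebus sabaeus) for cytotoxicity, read by MTT assay, with a stated time of 72 h (a lower number here means that less compound is tolerated, a higher number that more compound is tolerated), compound 1, `CC(C)Cc1ccc(C(=O)/C=C/c2ccc(C(=O)O)cc2)cc1`, gives < 10 ug/mL, a limit of the measurement rather than a number. Compound 2, `COC(=O)c1cc(-c2cccc(NC(=O)c3ccc(/C=C/C(=O)c4ccc(F)cc4)cc3)c2)on1`, gives > 20 ug/mL, again only a limit. Compound 3, `COC(=O)c1cc(-c2cccc(NC(=O)c3ccc(/C=C/C(=O)c4cccc(C(F)(F)F)c4)cc3)c2)on1`, gives > 20 ug/mL, which is likewise a limit. For the measured compounds named here, compound 3 therefore stands at the upper limit of this assay together with compound 2, and the only step between two measured compounds, a step that the two limits leave unreadable from compound 2 to compound 3, has a limit at both ends. The evidence is thin: the limit of < 10 ug/mL in this assay, at which 1 of the 3 values shown sits, and the limit of > 20 ug/mL in this assay, at which 2 of the 3 values shown sit, are all that the three measurements show.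

Compound 4, `COC(=O)c1cc(-c2cccc(NC(=O)c3ccc(/C=C/C(=O)c4ccccc4C)cc3)c2)on1`, differs from compound 3 in one place: 2-methylphenyl in place of 3-(trifluoromethyl)phenyl on a carbonyl carbon. Going by the values given here, no measured step involves a change of this kind, so its size cannot be drawn from any measured pair; the one measured step at that carbonyl carbon, from compound 2 to compound 3, sits at the limit at both ends. Compound 2 and compound 3 were both tolerated up to the limit. The step that the limit leaves unreadable from compound 3 to compound 4 is expected to stay within the usual scatter. The estimate for compound 4 in this assay is 25 ug/mL, ranging from 15 ug/mL to 50 ug/mL.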

Compound 4, half-maximal cytotoxic concentration: > 25 ug/mL
Compound 4 gave a limit, no number (the forecaster's own chance of this, stated with the estimate: 75%); the middle value lies on the limit itself.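

Compound 2, compound 3 and compound 4 each give a limit and no number, and the steps among them cannot be read. In this assay, the compounds shown leave open where the half-maximal cytotoxic concentrations of these three compounds actually lie, and whether changing the group on the carbonyl carbon alters tolerance at all.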